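A ring replaces an open chain on compound 2

A few compounds are considered here, and "the series" means these few. Any claim that something is new, unique, unknown or untested is made for them only; others in the source may bear on it.

Compound 1 `Cc1cc(=O)c2c(O)cc(OC/C=C/c3ccccc3)c([C@H]3CCN(C)C[C@H]3O)c2o1` gives 21%
Compound 2 `Cc1cc(=O)c2c(O)c(CN(C)CC(=O)O)c(O)c([C@H]3CCN(C)C[C@H]3O)c2o1` gives 23%
Compound 3 `Cc1cc(=O)c2c(O)c(CN3CCC(c4ccccc4)CC3)c(O)c([C@H]3CCN(C)C[C@H]3O)c2o1` gives 26%

All three compounds were tested in a functional assay on HL-60 cells (Homo sapiens) for inhibition, read by MTT assay, with a stated time of 48 h, tested at 10 uM (a higher number here means more inhibition of growth at the concentration tested, a lower number less inhibition of growth), and their values gather closely. Compound 2 at 23% lies within the usual scatter of repeated measurements of both compound 1 (21%) and compound 3 (26%), so its place among them cannot be told from noise. Going by the values given here, no two of these measured compounds differ in just one place, so no measured step shows how a single change acts here.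

Compound 4 `Cc1cc(=O)c2c(O)c(CN3CCCC3C(=O)O)c(O)c([C@H]3CCN(C)C[C@H]3O)c2o1` has not yet been measured. Its difference from compound 2 is 2-carboxypyrrolidin-1-yl in place of (carboxymethyl)(methyl)amino on a saturated chain carbon bound to an aromatic carbon and it sits on a saturated chain carbon bound to an aromatic carbon. The entering group brings a five-membered non-aromatic ring, whereas the leaving group has no ring.

In this assay no step beyond the scatter is expected, and neither direction is favoured. Among the compounds with values here, the estimate starts from compound 2, whose 23% is the only value tied to compound 4 by one change. The expected size of the change is small, with the estimated step of a number 1 percentage points higher from compound 2 to compound 4 (within the scatter) staying inside the scatter. Compound 4 is expected to give 24% (estimated range 12% to 38%).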

Compound 4, percent growth inhibition at one concentration: 16%
For compound 4 the middle estimate is 8 percentage points above the measured one; the range from low to high includes it.
By their numbers in this assay, from the lowest: compounds 4, 1, 2 and 3 (each within the scatter of the next).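

In this assay, the open chain at this place, on a saturated chain carbon bound to an aromatic carbon, gives way to a five-membered non-aromatic ring, and this provides the only single-change comparison among the compounds shown: a number 7 percentage points lower from compound 2 to compound 4 (within the scatter). Replacing (carboxymethyl)(methyl)amino with 2-carboxypyrrolidin-1-yl therefore adds a ring and keeps the counted hydrogen-bond donors and acceptors the same, yet produces no difference that can be told from the ordinary scatter of repeated measurements. No independent evidence bears on this result.

The compounds shown leave open whether a group of a different kind at this place, such as a simple primary amine or a longer chain ending in a carboxylic acid, would give a step beyond the scatter. A comparison of 2-carboxypyrrolidin-1-yl with plain pyrrolidin-1-yl, which lacks the carboxylic acid, would be needed to show whether that acid contributes anything to growth inhibition here.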